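Aminoalkyl Chain Without the Ester on a Chromanol Core

This account rests on a few compounds, and the source may have more. Where it says the series, first, only, none or still open, it means among the compounds named here.

Measured compounds:
compound 1 `Cc1c(C)c2c(c(C)c1O)CCC(C)(COc1ccc(/C=C3\SC(=O)N(C)C3=O)cc1)O2` — 127%
compound 2 `Cc1c(C)c2c(c(C)c1OC(=O)CCCCCCCN)CCC(C)(COc1ccc(/C=C3\SC(=O)N(C)C3=O)cc1)O2` — 54.4%

In an ADME assay on cells (Hepatocyte, Homo sapiens) for cytotoxicity, read by MTT assay, with a stated time of 90 min, tested at 200 uM (on this read-out higher numbers stand for a weaker effect at the one concentration tested and lower numbers for a stronger effect), compound 1 gives 127%, while compound 2 gives 54.4%. Compound 2 therefore holds the lowest of the two numbers, and its nearest neighbour is compound 1, which sits higher by the step of a number 72.6 percentage points lower from compound 1 to compound 2 (beyond the scatter). That step brought a (7-aminoheptyl)carbonyl in place of hydrogen on an oxygen on an aromatic ring.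

Compound 3 `Cc1c(C)c2c(c(C)c1CCCCCCN)CCC(C)(COc1ccc(/C=C3\SC(=O)N(C)C3=O)cc1)O2` has not yet been measured. It differs from compound 2 by the change (6-aminohexyl in place of ((7-aminoheptyl)carbonyl)oxy on an aromatic carbon). Among the measured compounds shown here, the only step on record, a number 72.6 percentage points lower from compound 1 to compound 2 (beyond the scatter), bears on it indirectly: compound 3 keeps an amino-terminated chain, as compound 2 does, but the ester linkage that compound 1 lacks is gone. The account thus places compound 3 between the two measured compounds in structure, and the expectation is an upward step in this assay, of moderate size, as compound 3 is expected to move by a number 17.6 percentage points higher from compound 2 to compound 3 (beyond the scatter). Compound 3 is accordingly estimated at 72%, within a range from 42% to 110%.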

Compound 3, a percentage reported as activity, at one concentration (the size of the read-out at that concentration, not a potency): 82.7%
Beside the measured number, compound 3's estimate is 10.7 percentage points below it; low and high end bracket the measured number.
By their numbers in this assay, from the lowest: compound 2; then compound 3; then compound 1.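

In this assay, putting 6-aminohexyl on the aromatic carbon in place of ((7-aminoheptyl)carbonyl)oxy gives a number 28.3 percentage points higher from compound 2 to compound 3 (beyond the scatter), so the read-out at this position depends on more than the presence of an amino-terminated chain. The step of a number 44.3 percentage points lower from compound 1 to compound 3 (beyond the scatter), which has 6-aminohexyl in place of hydroxy, shows that a chain with no ester linkage still lowers the number beyond the scatter, so the drop seen with compound 2 does not require the ester. No supporting data are available to explain either step.

The change from compound 2 to compound 3 alters the linkage and the chain at once, so these compounds cannot separate the two contributions. Going by these compounds, it also remains open how a plain hexyl chain without the amine, a 6-aminohexyl chain joined through an ether oxygen, or a longer aminoalkyl chain joined directly to the aromatic carbon would read here.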